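A few compounds are considered here, and "the series" means these few. Any claim that something is new, unique, unknown or untested is made for them only; others in the source may bear on it.

Compound 1 `CCOCCOC(=O)Nc1cc2nc(C3CCCCC3)[nH]c2cc1N(C)C` gives > 100 ug/mL in an ADME assay on Vero cells (Chlorocebus sabaeus) for cytotoxicity, read by resazurin assay, with a stated time of 3 days (on this read-out higher numbers stand for weaker inhibition and lower numbers for stronger inhibition), which is a limit of the assay rather than a number.
Compound 2 `CCCCOC(=O)Nc1cc2nc(C3CCCCC3)[nH]c2cc1N(CCC)CCC` gives > 100 ug/mL in this assay, again a limit.
Compound 3 `CCOCCOC(=O)Nc1cc2nc(C3CCCCC3)[nH]c2cc1N1CCCC1` gives > 100 ug/mL in this assay, once more a limit.

Compound 1 therefore has no number of its own in this assay; it sits at the limit, and the two other values shown sit there as well, so nothing places it higher or lower than compound 2 or compound 3. Among the compounds with values here, the one step measured in a single place, a step that the two limits leave unreadable from compound 1 to compound 3, stays unreadable, since both of its ends are limits.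

Compound 4 `CCCCCC(=O)Nc1cc2nc(C3CCCCC3)[nH]c2cc1N(C)C`, not yet measured, differs from compound 1 by pentyl in place of 2-ethoxyethoxy on a carbonyl carbon. Within the data shown here, no measured step touches the carbonyl carbon, so none bears directly on this change and no size can be taken from them. What the data do show is the limit of > 100 ug/mL in this assay, at which 3 of the 3 values shown sit; with that in view, the expectation for compound 4 in this assay is another limit rather than a readable step, in neither direction beyond the scatter. Compound 4 is estimated at 120 ug/mL, with a range from 50 ug/mL to 300 ug/mL. This expectation corresponds to a step that the limit leaves unreadable from compound 1 to compound 4.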

Compound 4, half-maximal inhibitory concentration: > 100 ug/mL
Compound 4: no number, only a limit (the forecaster's own chance of this, stated with the estimate: 80%); the middle value does not contradict the limit.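

In this assay, within the data shown here, compound 4 stops at a limit, as compound 1 does, so pentyl in place of 2-ethoxyethoxy on a carbonyl carbon gives no step that can be read. The compounds shown leave open what actual number any of them would reach in this assay and whether any change to them would shift it.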